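The source may report more compounds than this note shows. Statements on the series, on what has been measured and on what is new or still open speak of the compounds shown alone.

Measured so far:
compound 1, `COc1nn(Cc2ccc([N+](=O)[O-])cc2)c(=O)o1`, 18% in an assay on COS-7 cells for inhibition of Fatty-acid amide hydrolase 1 (Homo sapiens), read by scintillation counting, with a stated time of 10 min, tested at 10 uM; a higher number here means more inhibition at the concentration tested (going by the name of the read-out), a lower number less inhibition
compound 2, `COc1nn(Cc2ccc(N)cc2)c(=O)o1`, 34%
compound 3, `CCOc1nn(Cc2cccc([N+](=O)[O-])c2)c(=O)o1`, "not active" (no number reported)

Compound 1 and compound 2 share a core and differ in one place: amino in place of nitro on an aromatic carbon. This change made a step of a number 16 percentage points higher from compound 1 to compound 2 (beyond the scatter) in this assay, so compound 2 shows more inhibition than compound 1, by an amount that goes beyond the usual scatter of the measurement, though still modest.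

Compound 3 carries a different core, and the difference between the two cores is not broken down here. For compound 3 itself no single number is given in this assay; it is reported only as not active.

Compound 4, `CCOc1nn(Cc2cccc(N)c2)c(=O)o1`, has not yet been measured. It is related to compound 3 by the same kind of change that leads from compound 1 to compound 2: amino in place of nitro on an aromatic carbon. The surroundings of the change are not identical, however: in compound 1 the nitro sits para to a group of 9 heavy atoms, whereas in compound 3 it sits meta to a large group.

Going by the values given here, the step from compound 1 to compound 2 is the only guide available. Because that step was a number 16 percentage points higher from compound 1 to compound 2 (beyond the scatter), the expectation is a similar gain for compound 4 over compound 3, starting from a compound with no number reported. On that basis compound 4 is estimated at 15% in this assay, expected to fall between 0% and 35%.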

Compound 4, a percentage reported as inhibition, at one concentration (the size of the read-out at that concentration, not a potency): 10%
Beside the measured number, compound 4's estimate is 5 percentage points above it, within the range that was stated.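

In this assay, going by these compounds alone, compound 3 is reported as "not active" (no number reported) and compound 4 gives 10% so no step between these two compounds can be read. The compounds shown leave open whether amino in place of nitro, meta to a large group, brings the same gain as it does from compound 1 to compound 2. No measured evidence here bears on this result.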